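The source may hold more compounds than are shown below. What is called first, only, known or untested is meant among the compounds shown, and "the series" means these compounds.

Compound 3 `COCCCN1CCC(O)(CNC(=O)c2nc(C(C)C)n3ccccc23)CC1` is the weakest of the three measured compounds in a functional assay on CHO cells for agonist activity at 5-hydroxytryptamine receptor 4 (Homo sapiens), read by a luciferase reporter and cAMP accumulation, with a stated time of 4 h (a higher number here means that more compound is needed for the effect, a lower number that less compound is needed), where compound 3 gives 316 nM. The other two share its core but lack the ring hydroxyl and carry a ring on the amine nitrogen instead of a chain: compound 1 `CC(C)c1nc(C(=O)NCC2CCN(C3CCOCC3)CC2)c2ccccn12` gives 11 nM, and compound 2 `CC(C)c1nc(C(=O)NCC2CCN(C3CCC3)CC2)c2ccccn12` gives 9.8 nM. Compound 3 thus stands well apart from both, its nearest neighbour being compound 1.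

Compound 4 `CC(C)c1nc(C(=O)NCC2(O)CCN(CC(C)(C)O)CC2)c2ccccn12` keeps the hydroxylated ring of compound 3 and changes only the chain on the amine nitrogen: 1-hydroxy-1-methylethyl in place of 2-methoxyethyl on a saturated chain carbon bound to an amine nitrogen in a ring. Among the measured compounds shown here, no measured pair shows this particular exchange. For the measured compounds named here, the only step that touches the same nitrogen is a 1.1-fold lower number from compound 1 to compound 2 (0.05 log units; within the scatter), which replaced one ring with another and moved the number hardly at all. That step is a weak guide here, since it swaps rings rather than rearranging a chain and adding a hydrogen-bond donor. Going by the values given here, with no closer precedent, the expected step is small and in no clear direction, so compound 4 is estimated to remain close to compound 3, with a 1.3-fold lower number from compound 3 to compound 4 (0.10 log units; within the scatter). Compound 4 is therefore expected to give about 250 nM in this assay, within a range from 80 nM to 800 nM.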

Compound 4, half-maximal effective concentration: 72.3 nM
Compound 4: middle estimate off by 3.5-fold (0.54 log units), on the high side, and the stated range ends above it.
By their numbers in this assay, from the lowest: compounds 2 and 1 (each within the scatter of the next); then compound 4; then compound 3.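

At this position the arrangement of the chain matters: in this assay, putting 1-hydroxy-1-methylethyl in place of 2-methoxyethyl gives a 4.4-fold lower number from compound 3 to compound 4 (0.64 log units; beyond the scatter) even though both groups hold the same count of heavy atoms. Among the compounds shown here, the only earlier step at this amine nitrogen was a 1.1-fold lower number from compound 1 to compound 2 (0.05 log units; within the scatter) for one ring swapped for another, so this is the first change here that moves the number by more than the scatter, and the entering group carries a hydrogen-bond donor where the leaving group has none. No measurement here explains the shift, so that donor remains a difference between the two groups and not a demonstrated reason for it.

The exchange relocates the oxygen, replaces a methoxy group with a hydroxyl and branches the chain all at once, and the compounds shown do not pull these changes apart; a 2-methoxy-2-methylpropyl chain or a plain 2-methylpropyl chain on the same nitrogen would begin to do so. The contribution of the hydroxyl on the ring also stays open, as no pair shown differs in that feature alone.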